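Taking the fluoro group off compound 3

This account rests on a few compounds, and the source may have more. Where it says the series, first, only, none or still open, it means among the compounds named here.

Measured in a functional assay on cells (leukaemia cell line, Homo sapiens) for inhibition, read by sulforhodamine B assay, with a stated time of 48 h; on this read-out higher numbers stand for weaker inhibition of growth and lower numbers for stronger inhibition of growth:
Compound 1 `O=S(=O)(Nc1ccc(Cl)cc1Cl)c1ccc(-c2cnc(C3CC3)o2)cc1`: 74500 nM
Compound 2 `O=S(=O)(Nc1ccccc1Cl)c1ccc(-c2cnc(C3CC3)o2)cc1`: 49700 nM
Compound 3 `O=S(=O)(Nc1ccc(F)c(Cl)c1)c1ccc(-c2cnc(C3CC3)o2)cc1`: 73700 nM

Compound 3, at 73700 nM, cannot be told apart from the other two. The comparisons are a 1.0-fold lower number from compound 1 to compound 3 (0.00 log units; within the scatter) and a 1.5-fold higher number from compound 2 to compound 3 (0.17 log units; within the scatter).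

Compound 4 `O=S(=O)(Nc1cccc(Cl)c1)c1ccc(-c2cnc(C3CC3)o2)cc1` changes one atom of compound 3: hydrogen in place of fluoro on an aromatic carbon. This is hydrogen in place of fluoro on an aromatic carbon, ortho to a chloro group and para to a large group. The closest measured change puts hydrogen in place of chloro on an aromatic carbon, and it gave a 1.5-fold lower number from compound 1 to compound 2 (0.18 log units; within the scatter). No fluoro removal has been measured, so this is only a loose guide. The expected result is a 1.1-fold lower number from compound 3 to compound 4 (0.05 log units; within the scatter), a step no larger than the scatter. For compound 4 the estimated value is 65000 nM, with an expected range of 38000 nM to 100000 nM.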

Compound 4, concentration for total growth inhibition: 54200 nM
Compound 4: middle estimate off by 1.2-fold (0.08 log units), on the high side; low and high end bracket the measured number.
By their numbers in this assay, from the lowest: compounds 2, 4, 3 and 1 (each within the scatter of the next).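

In this assay putting hydrogen in place of the fluoro group gives a 1.4-fold lower number from compound 3 to compound 4 (0.13 log units; within the scatter) and so stays within the scatter, which means this position shows no need for fluoro. Likewise, 3-chlorophenyl in place of 2-chlorophenyl gives a 1.1-fold higher number from compound 2 to compound 4 (0.04 log units; within the scatter) and 3-chlorophenyl in place of 2,4-dichlorophenyl gives a 1.4-fold lower number from compound 1 to compound 4 (0.14 log units; within the scatter) and these groups on the sulfonamide nitrogen cannot be told apart here. No measurement available here explains these small steps.

As far as these compounds go, whether an amine or a carboxylic acid on this aromatic carbon would move the number beyond the scatter remains open.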